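The source may report more compounds than this note shows. Statements on the series, on what has been measured and on what is new or still open speak of the compounds shown alone.

Measured so far in a physicochemical assay for lipophilicity, read by HPLC, measured as octanol-water partition; on this read-out higher numbers stand for higher lipophilicity and lower numbers for lower lipophilicity:
- Compound 1 `CN1CCN(C[C@H]2CN(c3ccc(-n4cc(-c5ccccn5)cn4)c(F)c3)C(=O)O2)CC1`: 2.2
- Compound 2 `O=C1O[C@@H](Cn2ccnn2)CN1c1ccc(-n2cc(-c3ccccn3)cn2)c(F)c1`: 2

Within the data shown here, compound 2 stands at 2, within the scatter of compound 1 at 2.2, the only other measured compound. Compound 3 `CN(C)S(=O)(=O)NC[C@H]1CN(c2ccc(-n3cc(-c4ccccn4)cn3)c(F)c2)C(=O)O1` has not yet been measured. Its structure departs from that of compound 2 in one place, on a saturated chain carbon bound to a saturated ring carbon, where (dimethylsulfamoyl)amino takes the place of 1H-1,2,3-triazol-1-yl: (dimethylsulfamoyl)amino in place of 1H-1,2,3-triazol-1-yl on a saturated chain carbon bound to a saturated ring carbon. Among the measured compounds shown here, one measured step bears on this place: a number 0.20 log units lower from compound 1 to compound 2 (within the scatter). It is a single step, and it does not involve the entering group, so it is only a weak guide. No shift beyond the scatter is therefore expected in this assay, in either direction, and the estimated step is a number 0.10 log units higher from compound 2 to compound 3 (within the scatter). Compound 3 is expected at 2.1, with an estimated range from 1.6 to 2.6.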

Compound 3, partition coefficient: 1.38
Beside the measured number, compound 3's estimate is 0.72 log units above it; measured number outside the range, below it.
By their numbers in this assay, from the lowest: compound 3; then compounds 2 and 1 (each within the scatter of the next).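

In this assay, the position on a saturated chain carbon bound to a saturated ring carbon now proves able to move the number beyond the scatter, which the exchange of 4-methylpiperazin-1-yl for 1H-1,2,3-triazol-1-yl did not show. Putting (dimethylsulfamoyl)amino in place of 1H-1,2,3-triazol-1-yl brings a number 0.62 log units lower from compound 2 to compound 3 (beyond the scatter) and putting it in place of 4-methylpiperazin-1-yl brings a number 0.82 log units lower from compound 1 to compound 3 (beyond the scatter) so the drop holds against both earlier groups. Nothing available explains why this group shifts the number.

As far as these compounds go, what stays open is which part of (dimethylsulfamoyl)amino carries the step, since it enters as a whole. A methanesulfonamide, an acetamide or a primary amine at the same place would separate the sulfonyl unit, the dimethylamino end and the chain nitrogen, and whether the step holds on another core is also unknown.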